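The compounds below may be only part of what the source reports. "The series", "measured", "known", "first", "only" and "open" are said of these compounds alone.

Compound 3 `Clc1cccc(Nc2ccc(N3CC4CC(C3)N4)cn2)c1` gives the lowest number of the three measured compounds in an assay on cell membranes for displacement of a labelled ligand from Neuronal acetylcholine receptor; alpha4/beta2 (Rattus norvegicus) (a higher number here means a weaker inhibitor, a lower number a stronger inhibitor), at 2.2 nM. Compound 1 `CN(c1ccccc1)c1ccc(N2CC3CC(C2)N3)nn1` gives 1430 nM in this assay, and compound 2 `Clc1cccc(Nc2ccc(N3CC4CC(C3)N4)nn2)c1` gives 1540 nM; both stand far above compound 3, beyond the scatter, and compound 1 and compound 2 lie within the scatter of each other. Compound 4 `Cc1ccc(Nc2ccc(N3CC4CC(C3)N4)cn2)cc1` has not yet been measured. It differs from compound 3 in one place: 4-methylphenyl in place of 3-chlorophenyl on a nitrogen on an aromatic ring. Among the compounds with values here, no measured pair shows the effect of exchanging one substituted phenyl for another on this nitrogen, so the step is expected to be small, most likely a mild weakening of a 2.3-fold higher number from compound 3 to compound 4 (0.36 log units; beyond the scatter). Compound 4 is therefore estimated at 5 nM, between 1 nM and 25 nM.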

Compound 4, inhibition constant: 52.1 nM
For compound 4 the middle estimate is 10-fold (1.02 log units) below the measured one; measured number above the stated range.
By their numbers in this assay, from the lowest: compound 3; then compound 4; then compounds 1 and 2 (each within the scatter of the next).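

Exchanging 3-chlorophenyl for 4-methylphenyl on a nitrogen on an aromatic ring gives a 24-fold higher number from compound 3 to compound 4 (1.37 log units; beyond the scatter) in this assay. This position therefore distinguishes between two substituted phenyl groups of equal heavy-atom count, and a compound can lose much of its strength here while remaining far stronger than compound 1 and compound 2. Nothing available accounts for the size of this step.

Going by these compounds, the step changes both the substituent and its place on the phenyl ring, and it remains open which of the two matters. A 3-methylphenyl or 4-chlorophenyl group on this nitrogen would separate them.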